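The source may hold more compounds than are shown below. What is called first, only, known or untested is meant among the compounds shown, and "the series" means these compounds.

Working notes on the shared core of compound 1 `COc1ccccc1C(=O)Nc1ccc2[nH]cc(C3CCN(C)CC3)c2n1`, compound 2 `CN1CCC(c2c[nH]c3ccc(NC(=O)C4CCCCC4)nc23)CC1` and compound 3 `CN1CCC(c2c[nH]c3ccc(NC(=O)c4cccs4)nc23)CC1`, which differ only in the group on the carbonyl carbon. In an assay for binding affinity to 5-hydroxytryptamine receptor 1F (Homo sapiens), read by radioligand binding (on this read-out higher numbers stand for weaker inhibition and lower numbers for stronger inhibition), compound 1 gives 20 nM, compound 2 gives 20 nM and compound 3 gives 7.1 nM. Compound 1 therefore sits level with compound 2, the two highest of the three numbers; the steps are no change at the digits printed from compound 1 to compound 2 (within the scatter), a 2.8-fold lower number from compound 1 to compound 3 (0.45 log units; beyond the scatter) and a 2.8-fold lower number from compound 2 to compound 3 (0.45 log units; beyond the scatter). Compound 4 `CN1CCC(c2c[nH]c3ccc(NC(=O)c4ccncc4)nc23)CC1` carries pyridin-4-yl in place of 2-methoxyphenyl on a carbonyl carbon. Among the measured compounds shown here, the steps that bear on this exchange at the carbonyl carbon were small or absent, so only a small step, if any beyond the scatter, is expected in this assay from compound 1 to compound 4, more likely towards a lower number. For compound 4 a value of 15 nM is estimated, range 5 nM to 45 nM, corresponding to an expected 1.3-fold lower number from compound 1 to compound 4 (0.12 log units; within the scatter).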

Compound 4, inhibition constant: 8.4 nM
The estimate for compound 4 lay 1.8-fold (0.25 log units) above the measured number; the range from low to high includes it.
By their numbers in this assay, from the lowest: compounds 3 and 4 (each within the scatter of the next); then compounds 1 and 2 (each within the scatter of the next).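

In this assay, pyridin-4-yl on the carbonyl carbon sits with thiophen-2-yl (a 1.2-fold higher number from compound 3 to compound 4 (0.07 log units; within the scatter)) and apart from both 2-methoxyphenyl (a 2.4-fold lower number from compound 1 to compound 4 (0.38 log units; beyond the scatter)) and cyclohexyl (a 2.4-fold lower number from compound 2 to compound 4 (0.38 log units; beyond the scatter)). The lower level is therefore not unique to thiophen-2-yl, and a six-membered aromatic ring can reach it when that ring is pyridin-4-yl rather than 2-methoxyphenyl. No measurement on hand explains these differences. As far as these compounds go, whether the step from compound 1 follows the loss of methoxy or the entry of the ring nitrogen remains open. A plain phenyl group at this place would separate the two.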